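Cyano compounds: trifluoromethyl in place of chloro

The compounds below may be only part of what the source reports. "The series", "measured", "known", "first", "only" and "open" are said of these compounds alone.

In an ADME assay on L6 cells (Rattus norvegicus) for cytotoxicity, read by resazurin assay, with a stated time of 72 h (a lower number here means a stronger inhibitor, a higher number a weaker inhibitor), compound 3 `N#Cc1ccc(C(O)(c2ccc(Cl)cc2)c2cccnc2)cc1` gives > 100000 nM, which is a limit of the assay and not a number. In the same assay, compound 1 `OC(c1ccc(Cl)cc1)(c1ccc(C(F)(F)F)cc1)c1cccnc1` gives 56400 nM, and compound 2 `CC(C)Oc1ccc(C(O)(c2ccc(C(F)(F)F)cc2)c2cccnc2)cc1` gives 47600 nM. Compound 4 `N#Cc1ccc(C(O)(c2ccc(C(F)(F)F)cc2)c2cccnc2)cc1` differs from compound 3 by trifluoromethyl in place of chloro on an aromatic carbon, with trifluoromethyl in place of chloro on an aromatic carbon. For the measured compounds named here, two measured steps bear on this change. Isopropoxy in place of chloro gives a 1.2-fold lower number from compound 1 to compound 2 (0.07 log units; within the scatter). Cyano in place of trifluoromethyl gives an at least 1.7-fold higher number from compound 1 to compound 3 (0.24 log units; that floor lies within the scatter). Both steps are small, so only a modest move to a lower number is expected, not clearly beyond the scatter. The estimated step is an at least 1.4-fold lower number from compound 3 to compound 4 (0.15 log units; that floor lies within the scatter). The expected value for compound 4 is 70000 nM, with an estimated range of 38000 nM to 120000 nM.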

Compound 4, half-maximal inhibitory concentration: 76500 nM
Beside the measured number, compound 4's estimate is 1.1-fold (0.04 log units) below it; the measured number falls inside the stated range.
By their numbers in this assay, from the lowest: compounds 2, 1 and 4 (each within the scatter of the next). At a limit, above all of these: compound 3.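

In this assay compound 3 gives > 100000 nM as a limit of the assay and not a number. Trifluoromethyl in place of chloro on this aromatic carbon gives an at least 1.3-fold lower number from compound 3 to compound 4 (0.11 log units; that floor lies within the scatter) as a floor only: the limit of > 100000 nM in this assay, at which 1 of the 4 values shown sits. With trifluoromethyl kept, cyano in place of isopropoxy gives a 1.6-fold higher number from compound 2 to compound 4 (0.21 log units; within the scatter) and cyano in place of chloro gives a 1.4-fold higher number from compound 1 to compound 4 (0.13 log units; within the scatter) so chloro, isopropoxy and cyano show no separation at this place. As far as these compounds go, the true value of compound 3 stays open. So does whether an amine or a carboxylic acid at this place would give a step beyond the scatter.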